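The compounds below may be only part of what the source reports. "The series", "measured", "known", "first", "only" and "open" are said of these compounds alone.

Measured compounds:
- compound 1 `COc1ccc(SCc2ccc(C(=O)Nc3ccccc3N)cc2)cc1`: 2570 nM
- compound 2 `Nc1ccccc1NC(=O)/C=C/c1ccc(CSc2ccc(F)cc2)cc1`: 1190 nM

In a functional assay on A549 cells (Homo sapiens) for antiproliferative activity, read by CCK-8 assay, with a stated time of 72 h (on this read-out lower numbers stand for stronger inhibition and higher numbers for weaker inhibition), compound 1 holds the higher of the two numbers, so it is the weaker inhibitor of the pair, and the gap to compound 2 lies beyond the usual scatter. These two compounds differ in more than one place, so they do not show what a single small change does.

The next compound, compound 3 `Cc1ccc(SCc2ccc(C(=O)Nc3ccccc3N)cc2)cc1`, has methyl in place of methoxy on an aromatic carbon, para to a large group: methyl in place of methoxy on an aromatic carbon. The rest of the structure stays the same. Going by the values given here, with no measured step to go on, the expectation is none beyond the scatter, and no direction can be favoured: the estimated change is a 1.1-fold lower number from compound 1 to compound 3 (0.03 log units; within the scatter). The estimate for compound 3 is 2400 nM, with an expected range of 1100 nM to 5200 nM.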

Compound 3, half-maximal inhibitory concentration: 3270 nM
Beside the measured number, compound 3's estimate is 1.4-fold (0.13 log units) below it; the measured number falls inside the stated range.
By their numbers in this assay, from the lowest: compound 2; then compounds 1 and 3 (each within the scatter of the next).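

Going by these compounds alone, replacing 4-methoxyphenyl with 4-methylphenyl is the first single change that can be read here, and in this assay it gives a 1.3-fold higher number from compound 1 to compound 3 (0.10 log units; within the scatter) so the two compounds cannot be told apart. On this aromatic carbon, para to a large group, the methoxy oxygen with its hydrogen-bond acceptor can thus give way to methyl without a shift beyond the scatter, something the earlier pair, differing in more than one place, could not show. No measurement at hand explains this result or says what either group does in the cells.

The compounds shown leave open what an amine, a carboxylic acid or a longer chain such as ethoxy would do at this position. Also open, as far as these compounds go, is whether methyl in place of methoxy would give a similar step on the core of compound 2.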